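The compounds below may be only part of what the source reports. "The series", "measured", "known", "first", "only" and "open" are said of these compounds alone.

Of the compounds shown here, three built on one shared core have been measured in an assay on isolated protein for inhibition of alpha-ketoglutarate-dependent dioxygenase alkB homolog 3 (Homo sapiens), read by polymerase chain reaction, with a stated time of 1 h; on this read-out lower numbers stand for stronger inhibition and higher numbers for weaker inhibition. Compound 1 `Cc1[nH]n(-c2nc3cc(-c4ccccc4)ccc3[nH]2)c(=O)c1Cc1ccccc1` gives 810 nM. For the measured compounds named here, compound 2 `Cc1[nH]n(-c2nc3cc(Cl)ccc3[nH]2)c(=O)c1Cc1ccccc1` gives 4500 nM; between these two the single change was a 5.6-fold higher number from compound 1 to compound 2 (0.74 log units; beyond the scatter). Compound 3 `Cc1[nH]n(-c2nc3ccccc3[nH]2)c(=O)c1CC(=O)O` gives 15000 nM, the highest of the three numbers: it stands above compound 2 by a margin beyond the scatter, and further still above compound 1. Going by the values given here, compound 3 differs from each of the others in two places at once, so no single step links it to either of them.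

The next compound, compound 4 `Cc1[nH]n(-c2nc3ccccc3[nH]2)c(=O)c1Cc1ccc(Cl)cc1Cl`, is reached from compound 3 by one change: 2,4-dichlorophenyl in place of carboxy on a saturated chain carbon bound to an aromatic carbon. Among the compounds with values here, none of the measured steps covers this change; the only measured step, from compound 1 to compound 2, alters a different part of the molecule. What the values do show is that compound 1 and compound 2, which both carry an aromatic ring where compound 3 carries the carboxy, give lower numbers than compound 3, though each of them also differs from it at a second place. Compound 4 is therefore expected to give a lower number than compound 3, with the step of a 5.0-fold lower number from compound 3 to compound 4 (0.70 log units; beyond the scatter) estimated as modest. The estimate for compound 4 is 3000 nM, within a range from 800 nM to 12000 nM.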

Compound 4, half-maximal inhibitory concentration: > 10000 nM
Compound 4: a limit, no number (the forecaster's own chance of this, stated with the estimate: 5%); middle value at least 3.3-fold (0.52 log units) away from the limit.
By their numbers in this assay, from the lowest: compound 1; then compound 2; then compound 3.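

The step from compound 3 to compound 4 cannot be read, because compound 4 gives only a limit and not a number: the limit of > 10000 nM in this assay, at which 1 of the 4 values shown sits. The compounds shown leave open whether 2,4-dichlorophenyl in place of carboxy, on a saturated chain carbon bound to an aromatic carbon, gives a lower number, a higher number or much the same number.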